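Amine N-methylation on two related benzophenone-type cores

The compounds below may be only part of what the source reports. "The series", "measured", "known", "first", "only" and "open" are said of these compounds alone.

Measured compounds in a functional assay on HeLa cells (Homo sapiens) for antiproliferative activity, read by MTT assay, with a stated time of 48 h; on this read-out lower numbers stand for stronger inhibition and higher numbers for weaker inhibition:
Compound 1, `CNCC(=O)Nc1cc(OC)ccc1C(=O)c1ccc(OC)c2c1C=CC(C)(C)O2`: 2170 nM
Compound 2, `COc1ccc(C(=O)c2ccc(OC)c3c2C=CC(C)(C)O3)c(NC(=O)CN(C)C)c1`: 3620 nM
Compound 3, `C=C(c1ccc(OC)cc1NC(=O)CN)c1ccc(OC)c2c1C=CC(C)(C)O2`: 200 nM

Compounds 1 and 2 share one core; compound 3 carries a different core, and the difference between the two cores is not broken down here. Among the measured compounds shown here, compound 3 gives the lowest number of the three, and its gap to compound 1 and to compound 2 is in each case beyond the usual scatter, so compound 3 is the most active compound measured so far.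

Within the first core, the change methyl in place of hydrogen on an amine nitrogen gave a 1.7-fold higher number from compound 1 to compound 2 (0.22 log units; within the scatter). The unmeasured compound 4, `C=C(c1ccc(OC)cc1NC(=O)CNC)c1ccc(OC)c2c1C=CC(C)(C)O2`, applies the same kind of change to compound 3: methyl in place of hydrogen on an amine nitrogen. The two places are not identical: in the pair compound 1 to compound 2 the amine nitrogen carries two saturated chain carbons, whereas in the pair compound 3 to compound 4 it carries one saturated chain carbon. The step is therefore the same kind of change, not the same change.

For the measured compounds named here, with only one earlier instance, and that one within the scatter, the expectation for compound 4 rests on compound 3 giving 200 nM and on the small size of a 1.7-fold higher number from compound 1 to compound 2 (0.22 log units; within the scatter). The expected step is a 1.5-fold higher number from compound 3 to compound 4 (0.18 log units; within the scatter), a number close to that of compound 3 and within the scatter of it. Compound 4 is estimated at 300 nM in this assay, with a likely range from 120 nM to 800 nM.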

Compound 4, half-maximal inhibitory concentration: 500 nM
Estimate against measurement, compound 4: 1.7-fold (0.22 log units) below; the measured number falls inside the stated range.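

In this assay, methyl in place of hydrogen on an amine nitrogen gave a 2.5-fold higher number from compound 3 to compound 4 (0.40 log units; beyond the scatter), while the same kind of change on the other core gave a 1.7-fold higher number from compound 1 to compound 2 (0.22 log units; within the scatter). Only the step on the core of compound 3 lies beyond the scatter, yet the two steps cannot be told apart in size: the same change on two cores in this assay, a 1.7-fold higher number (0.22 log units; within the scatter) from compound 1 to compound 2 and a 2.5-fold higher number (0.40 log units; beyond the scatter) from compound 3 to compound 4, 1.5-fold (0.18 log units) apart, within the scatter of two such steps

This supports carrying the change between these two cores with a modest penalty at most, but it does not show that the two cores respond alike in general. Among the compounds shown here, the evidence is only two pairs, and the nitrogen is not in the same setting in each: it carries two saturated chain carbons in the pair of compound 1 and compound 2, and one saturated chain carbon in the pair of compound 3 and compound 4.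

Still open, from the compounds shown here alone, is whether a second methyl on the amine nitrogen of compound 4 would extend the step seen from compound 3 to compound 4, and how the plain amino group would read on the core of compound 1. Also open, going by these compounds, is how a longer chain, such as ethyl or propyl, on that nitrogen would read on either core.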